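This account rests on a few compounds, and the source may have more. Where it says the series, first, only, none or still open, it means among the compounds named here.

Compound 1 `O=C(/C=C\Nc1ccc(Cl)cc1)c1cn(-c2ccccc2)nc1-c1ccc(Cl)cc1`: 3670 nM in a functional assay on A549 cells (Homo sapiens) for antiproliferative activity, read by MTT assay, with a stated time of 48 h; on this read-out lower numbers stand for stronger inhibition and higher numbers for weaker inhibition
Compound 2 `O=C(/C=C\Nc1ccc(C(F)(F)F)cc1)c1cn(-c2ccccc2)nc1-c1ccc(Cl)cc1`: > 50000 nM in this assay, a limit of the assay
Compound 3 `COc1cc(-c2nn(-c3ccccc3)cc2C(=O)/C=C\Nc2ccc(Cl)cc2)cc(OC)c1OC`: 8670 nM in this assay

Compound 2 differs from compound 1 by trifluoromethyl in place of chloro on an aromatic carbon, and that single change gave an at least 13-fold higher number from compound 1 to compound 2 (1.13 log units; beyond the scatter). The reading for compound 2 is only a limit of the assay (the limit of > 50000 nM in this assay, at which 1 of the 3 values shown sits). Compound 3 carries the same chloro-bearing chain as compound 1, but the difference between the two cores is not broken down here; in this assay compound 3 has the higher number of the two measured as numbers, compound 1 standing nearest to it.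

Compound 4 `COc1cc(-c2nn(-c3ccccc3)cc2C(=O)/C=C\Nc2ccc(C(F)(F)F)cc2)cc(OC)c1OC` has not yet been measured in this assay. It differs from compound 3 by trifluoromethyl in place of chloro on an aromatic carbon, the same change at the same place as before. Resting on the step of an at least 13-fold higher number from compound 1 to compound 2 (1.13 log units; beyond the scatter), compound 4 is expected to land near 70000 nM, most likely reported only as a limit. That expectation means a step of an 8.1-fold higher number from compound 3 to compound 4 (0.91 log units; beyond the scatter).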

Compound 4, half-maximal inhibitory concentration: > 50000 nM
Compound 4: a limit, no number; the forecaster's own chance of this, stated with the estimate: 70%; the middle value does not contradict the limit.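

In this assay, trifluoromethyl in place of chloro gave an at least 5.7-fold higher number from compound 3 to compound 4 (0.76 log units; beyond the scatter) on the trimethoxyphenyl-bearing core, so the change weakened inhibition on both cores shown. For the compounds shown here, this is only two cores, and it does not show that the change has the same size on each, since compound 2 and compound 4 both stand at a limit of the assay: the same change on two cores in this assay, an at least 13-fold higher number (1.13 log units; beyond the scatter) from compound 1 to compound 2 and an at least 5.7-fold higher number (0.76 log units; beyond the scatter) from compound 3 to compound 4; the limit leaves it open whether they differ. For the same reason, the step between compound 2 and compound 4 cannot be read.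

The compounds shown leave open how a nitrile or a dimethylamino group would read in place of chloro on this ring. They also leave open what numbers lie behind the two limits.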